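The source may hold more compounds than are shown below. What is called first, only, known or untested is meant among the compounds shown, and "the series" means these compounds.

Of the compounds shown here, three have so far been tested in a functional assay on DU-145 cells (Homo sapiens) for inhibition, read by trypan blue exclusion, with a stated time of 96 h; a lower number here means a stronger inhibitor of growth, a higher number a weaker inhibitor of growth. Compound 3 `CSc1ccc(/C=C(\C(=O)c2ccc(Br)cc2)S(=O)(=O)c2ccc(C)cc2)cc1` gives 1000 nM in this assay. Compound 1 `CSc1ccc(/C=C(\C(=O)c2ccc(Br)cc2)S(=O)(=O)Cc2ccc(C)cc2)cc1` shares the core of compound 3, and in this assay compound 1 gives 10000 nM. Going by the values given here, the only change between them is 4-methylbenzyl in place of 4-methylphenyl on a sulfonyl sulfur, and that change made a 10-fold higher number from compound 3 to compound 1 (1.00 log units; beyond the scatter). Compound 2 `Cc1ccc(S(=O)(=O)/C(=C/c2c(O)cc(O)cc2O)C(=O)c2ccc(Cl)cc2)cc1` is built on a different core; how the core of compound 2 differs from that of compound 3 is not broken down here. In this assay compound 2 gives > 100000 nM, which is a limit of the assay and not a number. That value sits at the limit of > 100000 nM in this assay, at which 1 of the 3 values shown sits.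

Compound 4 `Cc1ccc(CS(=O)(=O)/C(=C/c2c(O)cc(O)cc2O)C(=O)c2ccc(Cl)cc2)cc1` has not yet been measured. Among the compounds with values here, it differs from compound 2 by 4-methylbenzyl in place of 4-methylphenyl on a sulfonyl sulfur, the same change as the one from compound 3 to compound 1, made at the same place. Within the data shown here, because that change made a 10-fold higher number from compound 3 to compound 1 (1.00 log units; beyond the scatter) when it was measured, compound 4 is expected to show a step that the limit leaves unreadable from compound 2 to compound 4 in this assay, and no step in the other direction. Compound 4 is therefore estimated at 150000 nM in this assay, with an expected range from 50000 nM to 1000000 nM. Since compound 2 already gives only a limit, it is expected that the assay will again report only a limit for compound 4 rather than a number.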

Compound 4, concentration for 50% growth inhibition: > 100000 nM
Compound 4 gave a limit, no number (the forecaster's own chance of this, stated with the estimate: 85%); the middle value does not contradict the limit.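

In this assay compound 4 gives > 100000 nM, which is a limit of the assay and not a number. Compound 2 also gives only a limit, so no step can be read from compound 2 to compound 4: the limit of > 100000 nM in this assay, at which 2 of the 4 values shown sit.

The compounds shown leave open whether 4-methylbenzyl in place of 4-methylphenyl on the sulfonyl sulfur acts on the core of compound 2 as it does on the core of compound 3.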